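The compounds below may be only part of what the source reports. "The series", "measured", "known", "first", "only" and "open" are said of these compounds alone.

Measured so far:
compound 1 `COC(=O)N1C[C@H](NC(=O)OCCCCC2CCCCC2)C1=O` — 7180 nM
compound 2 `C[C@H]1[C@H](NC(=O)OCCCCC2CCCCC2)C(=O)N1OCCCS(C)(=O)=O` — 49 nM

In an assay on HEK293 cells for inhibition of N-acylethanolamine-hydrolyzing acid amidase (Homo sapiens), read by fluorescence, with stated times of 10 min and 50 min (a higher number here means a weaker inhibitor, a lower number a stronger inhibitor), compound 2 gives 49 nM, the lowest of the two numbers. Compound 1 gives 7180 nM, a far higher number, beyond the scatter. Compound 3 `COC(=O)c1ccc(ON2C(=O)[C@@H](NC(=O)OCCCCC3CCCCC3)[C@@H]2C)cc1` differs from compound 2 by 4-(methoxycarbonyl)phenyl in place of 3-(methylsulfonyl)propyl on an oxygen. Among the measured compounds shown here, no measured pair shows this change, so its size is unknown; a step near the scatter, in either direction, is expected rather than a large one. Compound 3 is estimated at 80 nM in this assay, with a range of 20 nM to 400 nM. The expected step is a 1.6-fold higher number from compound 2 to compound 3 (0.21 log units; within the scatter).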

Compound 3, half-maximal inhibitory concentration: 17 nM
The estimate for compound 3 lay 4.7-fold (0.67 log units) above the measured number; measured number outside the range, below it.
By their numbers in this assay, from the lowest: compound 3; then compound 2; then compound 1.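

In this assay, 4-(methoxycarbonyl)phenyl in place of 3-(methylsulfonyl)propyl on the oxygen bonded to the amide-type nitrogen in a ring gives a 2.9-fold lower number from compound 2 to compound 3 (0.46 log units; beyond the scatter) as a modest gain. This position therefore accepts a six-membered aromatic ring of carbon only as well as an open chain, without loss of inhibition. No available evidence bears on the reason for this step.

Going by these compounds, whether the gain follows from the ring or from the ester remains open. An unsubstituted phenyl, or a carboxylic acid in place of the methyl ester, on the same oxygen would separate the two.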